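Replacing nitro with methoxy in compound 3

The source may report more compounds than this note shows. Statements on the series, on what has been measured and on what is new or still open speak of the compounds shown alone.

Values in an ADME assay on L6 cells (Rattus norvegicus) for cytotoxicity, read by resazurin assay, with a stated time of 72 h (a higher number here means a weaker inhibitor, a lower number a stronger inhibitor), so far:
- compound 1 `N=C(N)c1cccc(OCc2ccccc2)c1` gives 156000000 nM
- compound 2 `N=C(N)c1cccc(OCc2cccc([N+](=O)[O-])c2)c1` gives 78900000 nM
- compound 3 `N=C(N)c1ccc(COc2ccc([N+](=O)[O-])cc2)cc1` gives 79200000 nM

Compound 3 stands within the scatter of both compound 1 and compound 2, so the three values are not separated. Compound 4 `COc1ccc(OCc2ccc(C(=N)N)cc2)cc1` remains unmeasured and differs from compound 3 as follows: methoxy in place of nitro on an aromatic carbon. This is methoxy in place of nitro on an aromatic carbon. For the measured compounds named here, one measured step bears on it, also at a nitro group: a 2.0-fold lower number from compound 1 to compound 2 (0.30 log units; within the scatter). No shift beyond the scatter is therefore expected in this assay. The estimated change is a 1.3-fold higher number from compound 3 to compound 4 (0.10 log units; within the scatter) (direction not resolved). Compound 4 is expected at 100000000 nM (estimated range 40000000 nM to 220000000 nM).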

Compound 4, half-maximal inhibitory concentration: 143000000 nM
Estimate against measurement, compound 4: 1.4-fold (0.16 log units) below; measured number inside the range.
By their numbers in this assay, from the lowest: compounds 2, 3, 4 and 1 (each within the scatter of the next).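

On an aromatic carbon para to a large group, methoxy in place of nitro gives a 1.8-fold higher number from compound 3 to compound 4 (0.26 log units; within the scatter) in this assay and so does not separate the two compounds. For the compounds shown here, until now the only single-place step was nitro in place of hydrogen, and this exchange of one substituent for another also stays within the scatter. No available evidence bears on this result.

As far as these compounds go, whether an amine, a carboxylic acid or a longer chain at this position would give a shift beyond the scatter remains open.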